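The compounds below may be only part of what the source reports. "The series", "measured", "known", "first", "only" and "open" are said of these compounds alone.

Measured so far, in an ADME assay on membranes from Cortex for displacement of a labelled ligand from Adrenergic receptor alpha-1 (Rattus norvegicus), read by radioligand binding, with a stated time of 60 min; a lower number here means a stronger inhibitor, a higher number a weaker inhibitor:
- compound 1, `c1ccc(-c2c3c(nn2C2CCC2)CCNCC3)cc1`, gives 500 nM
- compound 2, `CC(C)n1nc2c(c1-c1ccc(F)cc1)CCNCC2`, gives 170 nM

Of these two numbers compound 2 has the lower one, and the gap to compound 1 is beyond the usual scatter, so compound 2 is the stronger inhibitor of the pair. Compound 1 and compound 2 differ from each other in more than one place, so their gap cannot be tied to any single change.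

Compound 3, `Fc1ccc(-c2c3c(nn2C2CCC2)CCNCC3)cc1`, is not yet measured. Starting from compound 2, the change is cyclobutyl in place of isopropyl on an aromatic nitrogen. Among the compounds with values here, no pair of measured compounds isolates this swap, so the size of the step is open. Both groups are small hydrocarbon groups, and compound 1, which carries the cyclobutyl, stands only moderately higher than compound 2, so a step in either direction, or none beyond the scatter, would fit what is known. The expected outcome is a modest weakening, a 1.5-fold higher number from compound 2 to compound 3 (0.18 log units; within the scatter), giving an estimated value for compound 3 of 260 nM, with a likely range from 110 nM to 600 nM.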

Compound 3, inhibition constant: 220 nM
Estimate against measurement, compound 3: 1.2-fold (0.07 log units) above; low and high end bracket the measured number.
By their numbers in this assay, from the lowest: compounds 2 and 3 (each within the scatter of the next); then compound 1.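

In this assay, the swap of isopropyl for cyclobutyl on the aromatic nitrogen can now be read on its own: the step is a 1.3-fold higher number from compound 2 to compound 3 (0.11 log units; within the scatter), so at this position the assay does not separate the two groups, even though cyclobutyl brings a four-membered ring of carbon that isopropyl lacks. Compound 3 also isolates a second change, fluoro in place of hydrogen on an aromatic carbon, and here the step of a 2.3-fold lower number from compound 1 to compound 3 (0.36 log units; beyond the scatter) is modest but beyond the scatter, which places most of the gap between compound 1 and compound 2 with the fluoro change rather than the nitrogen group. No measurement at hand gives a reason for either step.

On these data alone, the fluoro step is read only with cyclobutyl on the nitrogen, so its size alongside isopropyl remains open, as does whether chloro or methoxy in place of the fluoro would give a similar step. The compounds shown also carry only small hydrocarbon groups on the aromatic nitrogen, which leaves open what a benzyl group or a chain ending in an amine would do there.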